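The compounds below may be only part of what the source reports. "The series", "measured", "known", "first", "only" and "open" are said of these compounds alone.

Compound 3, `O=C(NO)c1ccc(-c2cn([C@H]3C[C@H](CO)N(CCCc4ccccc4)C3)nn2)cc1`, is the only one of the three measured compounds to return a number in an assay on Sf9 cells for inhibition of histone deacetylase 11 (Homo sapiens), read by fluorescence, tested at 0.5 uM (a higher number here means more inhibition at the concentration tested (going by the name of the read-out), a lower number less inhibition), where compound 3 gives 18%. Compound 1, `O=C(NO)c1ccc(-c2cn([C@@H]3C[C@@H](CO)N(Cc4ccccc4)C3)nn2)cc1`, returns only a limit in this assay, at which compound 1 gives < 10%. Compound 2, `O=C(NO)c1cccc(-c2cn([C@@H]3C[C@@H](CO)N(CCCc4ccccc4)C3)nn2)c1`, likewise sits at a limit in this assay, where compound 2 gives < 10%. The limit of the limit of < 10% in this assay, at which 2 of the 3 values shown sit, frames what is known so far, and compound 3 stands just above it.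

Compound 4, `O=C(NO)c1ccc(-c2cn([C@@H]3C[C@@H](CO)N(CCCc4ccccc4)C3)nn2)cc1`, is related to compound 3 as follows: the two compounds have the same atoms and bonds and differ only in configuration as drawn: 2 of 2 stereo elements differ (all stereocentres are inverted: mirror images); a stereocentre at a saturated ring carbon is drawn S in compound 3 and R in compound 4; a stereocentre at a saturated ring carbon is drawn R in compound 3 and S in compound 4. Within the data shown here, no measured pair in this set separates such a change in configuration, so there is no step to lean on. Given that compound 3 gives 18%, the step from compound 3 to compound 4 is expected to be small, a number 6 percentage points lower from compound 3 to compound 4 (within the scatter), and may well not exceed the scatter. Compound 4 is therefore estimated at 12% in this assay, within a range from 0% to 25%.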

Compound 4, a percentage reported as inhibition, at one concentration (the size of the read-out at that concentration, not a potency): 14%
For compound 4 the middle estimate is 2 percentage points below the measured one; the measured number falls inside the stated range.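

Inverting both stereocentres gives a number 4 percentage points lower from compound 3 to compound 4 (within the scatter) in this assay, so this assay does not separate the two mirror images, and only one thing changes in this comparison: the fact that compounds 3 and 4 differ only in the configuration as drawn. Setting 4-(hydroxycarbamoyl)phenyl in place of 3-(hydroxycarbamoyl)phenyl gives a number at least 4 percentage points higher from compound 2 to compound 4 (that floor lies within the scatter), and setting phenethyl in place of phenyl gives a number at least 4 percentage points higher from compound 1 to compound 4 (that floor lies within the scatter). Both of these steps start from a limit of the assay, so each gives only a floor, and neither change can be credited with a real gain.

The compounds shown leave open whether a carboxylic acid in place of the hydroxycarbamoyl group, or a longer chain in place of phenethyl, would carry the reading in this assay clear of the scatter. They also leave open whether inverting only one of the two stereocentres would change the reading.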